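The source may report more compounds than this note shows. Statements on the series, on what has been measured and on what is new or still open speak of the compounds shown alone.

Compound 1 `COc1cc(-c2nn(-c3cccc(NC(=O)c4ccc(Cl)c(C(F)(F)F)c4)c3)cc2-c2ccncc2)ccc1Cl` is tested in a functional assay on SNB-19 cells (Homo sapiens) for inhibition, read by sulforhodamine B assay, with a stated time of 48 h (on this read-out lower numbers stand for stronger inhibition of growth and higher numbers for weaker inhibition of growth), where compound 1 gives 8680 nM. Among the three measured compounds this is the highest number: compound 3 `O=C(Nc1cccc(-n2cc(-c3ccncc3)c(-c3ccc(Cl)c(O)c3)n2)c1)Nc1ccc(Cl)c(C(F)(F)F)c1` gives 1120 nM and compound 2 `O=C(Nc1cccc(-n2cc(-c3ccncc3)c(-c3ccc(Cl)c(O)c3)n2)c1)Nc1cc(C(F)(F)F)cc(C(F)(F)F)c1` gives 983 nM, both well below compound 1, beyond the usual scatter. Those two compounds differ from compound 1 in more than one place, so no single step can be read from them. Compound 4 `COc1cc(-c2nn(-c3cccc(NC(=O)Nc4ccc(Cl)c(Cl)c4)c3)cc2-c2ccncc2)ccc1Cl` has not been measured; it differs from compound 1 by (3,4-dichlorophenyl)amino in place of 4-chloro-3-(trifluoromethyl)phenyl on a carbonyl carbon. Because compound 2 gives 983 nM and compound 3 gives 1120 nM in this assay, both far below compound 1, compound 4 is expected to show a downward step of a 3.5-fold lower number from compound 1 to compound 4 (0.54 log units; beyond the scatter), beyond the scatter. The estimate for compound 4 is 2500 nM, within a range of 800 nM to 8000 nM.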

Compound 4, concentration for 50% growth inhibition: 1720 nM
Compound 4: middle estimate off by 1.5-fold (0.16 log units), on the high side; the measured number falls inside the stated range.
By their numbers in this assay, from the lowest: compounds 2, 3 and 4 (each within the scatter of the next); then compound 1.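

In this assay, among these compounds, the first step that can be read at this position, on a carbonyl carbon, is a 5.0-fold lower number from compound 1 to compound 4 (0.70 log units; beyond the scatter). The swap adds an amino nitrogen and changes the ring substituents together, so a single step cannot divide the gain between those two changes. Nothing measured here explains the step.

Open, from the compounds shown here alone, is whether the same amino link carrying 4-chloro-3-(trifluoromethyl)phenyl would match compound 4. Also open, going by these compounds, is how a non-aromatic group on the carbonyl carbon, such as cyclohexylamino, would compare.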